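The source may hold more compounds than are shown below. What is called first, only, known or untested is meant among the compounds shown, and "the series" means these compounds.

Measured in a functional assay on BL2 cells for cytotoxicity, read by MTT assay, with a stated time of 24 h; a higher number here means a weaker inhibitor, a lower number a stronger inhibitor:
- compound 1 `CC(C)=CCC[C@H](C)[C@H]1C=C[C@@]2(C(=O)O)[C@H](CC(C)=C[C@@H]2/C=C(\C)[C@H]2CC[C@H](C(=O)O)CC2)C1`: > 20000 nM
- compound 2 `CC(C)=CCC[C@@H](C)[C@@H]1C=C[C@]2(C(=O)O)[C@@H](CC(C)=C[C@H]2/C=C(\C)[C@H]2CC[C@H](C(=O)O)CC2)C1`: > 20000 nM
- compound 3 `CC(C)=CCC[C@H](C)[C@@H]1C=C[C@]2(C(=O)O)[C@@H](CC(C)=C[C@H]2/C=C(\C)c2ccc(C(=O)O)cc2)C1`: > 20000 nM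

All three entries are limits, not numbers. Compound 3 stands at > 20000 nM, a limit of this assay.

Compound 4 `CC(C)=CCC[C@@H](C)[C@@H]1C=C[C@]2(C(=O)O)[C@@H](CC(C)=C[C@H]2/C=C(\C)c2ccc(C(=O)O)cc2)C1` is the next case: the two compounds have the same atoms and bonds and differ only in configuration as drawn: 1 of 6 stereo elements differ; a stereocentre at a saturated chain carbon is drawn S in compound 3 and R in compound 4. A stereocentre at a saturated chain carbon is drawn S in compound 3 and R in compound 4.

Within the data shown here, the one measured step of this kind is a step that the two limits leave unreadable from compound 1 to compound 2. It rests on the fact that compounds 1 and 2 differ only in the configuration as drawn and on (the limit of > 20000 nM in this assay, at which 3 of the 3 values shown sit), so it sets no size. The expected step, a step that the limit leaves unreadable from compound 3 to compound 4, is none beyond the scatter, in either direction.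

Compound 4 is estimated at 22000 nM, with an expected range of 15000 nM to 40000 nM.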

Compound 4, half-maximal inhibitory concentration: 8500 nM
Estimate against measurement, compound 4: 2.6-fold (0.41 log units) above; the whole stated range lies above it.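

In this assay, drawing the saturated chain stereocentre R instead of S gives an at least 2.3-fold lower number from compound 3 to compound 4 (0.37 log units; beyond the scatter), the first readable effect of configuration in this series. With that configuration, 4-carboxyphenyl in place of 4-carboxycyclohexyl gives an at least 2.3-fold lower number from compound 2 to compound 4 (0.37 log units; beyond the scatter), so the change at this position also registers. Only compound 4 combines both features, while compound 2 and compound 3 each carry one and remain at the assay limit.

Going by these compounds, the true size of both steps stays open, as each is bounded by a limit. Also open, on these data alone, is whether a methyl ester or an amine in place of the carboxylic acid on the 4-carboxyphenyl group would keep this value.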